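Uracil to dichloropurine on the shared core

The compounds below may be only part of what the source reports. "The series", "measured", "known", "first", "only" and "open" are said of these compounds alone.

Among the compounds with values here, in a functional assay on MCF7 cells (Homo sapiens) for cytotoxicity, read by sulforhodamine B assay, with a stated time of 3 days (on this read-out lower numbers stand for stronger inhibition and higher numbers for weaker inhibition), compound 1 `O=c1cc[nH]c(=O)n1C1CN(S(=O)(=O)c2ccccc2[N+](=O)[O-])c2ccccc2CO1` gives 50900 nM, the higher of the two numbers known so far. Compound 2 `O=[N+]([O-])c1ccc(S(=O)(=O)N2C[C@H](n3cnc4c(Cl)nc(Cl)nc43)OCc3ccccc32)cc1`, which carries the dichloropurine group, gives 190 nM, a gap beyond the scatter. Compound 3 `O=[N+]([O-])c1ccccc1S(=O)(=O)N1CC(n2cnc3c(Cl)nc(Cl)nc32)OCc2ccccc21` is the unmeasured analogue in which (a group of 11 heavy atoms (5 carbon, 4 nitrogen, 2 chlorine; one five-membered aromatic ring with 2 hetero atoms, one six-membered aromatic ring with 2 hetero atoms) in place of a group of 8 heavy atoms (4 carbon, 2 nitrogen, 2 oxygen; one six-membered aromatic ring with 2 hetero atoms), on a saturated ring carbon). Within the data shown here, no step between measured compounds covers this change, so the size is read from compound 2 alone; its value of 190 nM points to a large drop, well beyond the scatter. Compound 3 is expected to give 500 nM, between 100 nM and 3000 nM. This estimate implies an expected 100-fold lower number from compound 1 to compound 3 (2.01 log units; beyond the scatter).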

Compound 3, half-maximal inhibitory concentration: 383 nM
Compound 3: middle estimate off by 1.3-fold (0.12 log units), on the high side; the range from low to high includes it.
By their numbers in this assay, from the lowest: compounds 2 and 3 (each within the scatter of the next); then compound 1.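

In this assay, the exchange on the saturated ring carbon next to the ring oxygen now has a size on a pair differing in this one place: a 130-fold lower number from compound 1 to compound 3 (2.12 log units; beyond the scatter). The group of 11 heavy atoms thus accounts for a large change with the rest of compound 3 held as in compound 1. Nothing available bears on the cause of this step.

As far as these compounds go, whether the number holds with an amine in place of either chlorine remains open. So does the outcome with a smaller group at this carbon, such as a single imidazole ring.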